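Swapping the Aryl Group on the Anilino Nitrogen

The source may hold more compounds than are shown below. What is called first, only, known or untested is meant among the compounds shown, and "the series" means these compounds.

Measured compounds:
Compound 1 `COc1cc2ncnc(Nc3cccc(C(F)(F)F)c3)c2cc1OCCCSc1nc2ccccc2s1`: 4050 nM
Compound 2 `COc1ccc(Nc2ncnc3cc(OC)c(OCCCSc4nc5ccccc5s4)cc23)cc1`: 14200 nM
Compound 3 `COc1cc2ncnc(Nc3cccc(C(F)(F)F)c3)c2cc1OCCCSc1nc2ccccc2o1`: 4030 nM

All three numbers come from a functional assay on MCF7 cells (Homo sapiens) for cytotoxicity, read by MTT assay, with a stated time of 24 h; on this read-out lower numbers stand for stronger inhibition and higher numbers for weaker inhibition. Compound 3 and compound 1 give numbers that sit within the scatter of each other (a 1.0-fold lower number from compound 1 to compound 3 (0.00 log units; within the scatter)), while compound 2 gives a clearly higher number; on these values compound 3 stands at the low end. Compound 4 `COc1cc2ncnc(Nc3ccc(C)cc3)c2cc1OCCCSc1nc2ccccc2o1` differs from compound 3 by 4-methylphenyl in place of 3-(trifluoromethyl)phenyl on a nitrogen on an aromatic ring. Among the measured compounds shown here, one measured step bears on this change, a swap of the aryl group on the same nitrogen: a 3.5-fold higher number from compound 1 to compound 2 (0.54 log units; beyond the scatter). A weakening of similar size is therefore expected, so the step is estimated at a 2.7-fold higher number from compound 3 to compound 4 (0.44 log units; beyond the scatter). Compound 4 is expected to give 11000 nM, with a range from 5000 nM to 30000 nM.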

Compound 4, half-maximal inhibitory concentration: 12100 nM
Compound 4: the middle estimate sits 1.1-fold (0.04 log units) below what was measured, and the stated range covers the measured number.
By their numbers in this assay, from the lowest: compounds 3 and 1 (each within the scatter of the next); then compounds 4 and 2 (each within the scatter of the next).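

In this assay, the change to 4-methylphenyl gives a 3.0-fold higher number from compound 3 to compound 4 (0.48 log units; beyond the scatter), so replacing 3-(trifluoromethyl)phenyl on this nitrogen weakens inhibition with a 1,3-benzoxazol-2-yl on the sulfur as well as with the 1,3-benzothiazol-2-yl of the earlier pair. The loss also appears with a methyl group on the entering aryl, not only with the methoxy of compound 2. No measurement here gives a reason for it.

Both swaps remove the trifluoromethyl and alter the substituent's place together, so these two changes cannot be told apart. A 3-methylphenyl or 4-(trifluoromethyl)phenyl group on this nitrogen would separate them.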